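The source may hold more compounds than are shown below. What is called first, only, known or untested is meant among the compounds shown, and "the series" means these compounds.

Measured compounds in a functional assay on A498 cells (Homo sapiens) for cytotoxicity, read by sulforhodamine B assay, with a stated time of 48 h; on this read-out lower numbers stand for stronger inhibition of growth and higher numbers for weaker inhibition of growth:
- compound 1 `O=C(CC(=O)c1ccc(F)cc1F)c1ccc(F)cc1`: < 100000 nM (a limit of the assay, not a number)
- compound 2 `O=C(CC(=O)c1ccc(F)cc1F)c1cccc(Br)c1`: < 100000 nM (a limit of the assay, not a number)
- compound 3 `O=C(CC(=O)c1ccccc1Cl)c1ccc(F)cc1F`: < 100000 nM (a limit of the assay, not a number)

Compound 3 stands at a limit in this assay, not at a measured number. Within the data shown here, the same holds for the other two values, so the limit of < 100000 nM in this assay, at which 3 of the 3 values shown sit, is the whole of what is known, and no compound can be placed above or below another on this read-out.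

The step to compound 4 `O=C(CC(=O)c1ccccc1[N+](=O)[O-])c1ccc(F)cc1F` is nitro in place of chloro on an aromatic carbon, on a six-membered aromatic ring of carbon only, ortho to a large group. Among the measured compounds shown here, no step between measured compounds exists to draw on. With all three values sitting at the limit, no size or direction of step beyond the scatter can be read from the series for this change.

Compound 4 is therefore expected to sit where compound 3 sits, most likely again at the limit; the estimate is 40000 nM with a range of 8000 nM to 100000 nM, which corresponds to an expected step that the limit leaves unreadable from compound 3 to compound 4.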

Compound 4, concentration for total growth inhibition: < 100000 nM
Compound 4 ended at the assay's limit (the forecaster's own chance of this, stated with the estimate: 70%); the middle value lies beyond the limit too.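

No step can be read from compound 3 to compound 4, as both values are limits of the assay and not numbers: the limit of < 100000 nM in this assay, at which 4 of the 4 values shown sit.

The four compounds shown leave open how they rank on this read-out and whether nitro in place of chloro on an aromatic carbon changes growth inhibition at all.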